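The compounds below may be only part of what the source reports. "The series", "measured", "known", "first", "only" and "open" are said of these compounds alone.

Measured compounds:

Compound 1, `CO[C@@H](C(=O)NC1CC[C@@H](OC(=O)CC2CCCCC2)CNC1=O)[C@H](O)[C@@H](O)[C@H](O)/C=C/C(C)(C)C`, gives 60 nM in an in vivo functional assay on the whole organism (MDA-MB-435 cells, Homo sapiens) for antiproliferative activity; a higher number here means a weaker inhibitor, a lower number a stronger inhibitor.
Compound 2, `CCCCCCCCCCc1ccc(C(=O)O[C@@H]2CCC(NC(=O)[C@H](OC)[C@H](O)[C@@H](O)[C@H](O)/C=C/C(C)(C)C)C(=O)NC2)cc1`, gives 30 nM in this assay.
Compound 3, `CCCCCCCCCCCCCC(=O)O[C@H]1CCC(NC(=O)[C@H](OC)[C@H](O)[C@@H](O)[C@H](O)/C=C/C(C)(C)C)C(=O)N(C)C1`, gives 10 nM in this assay.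

Among these three, compound 1 has the highest number. Compound 2 sits closest to it, and the gap between the two lies within the usual scatter, so nothing separates them. Compound 3 sits furthest away, and its gap to compound 1 is beyond the scatter, so compound 3 is the stronger inhibitor of that pair.

Compound 4, `CO[C@@H](C(=O)NC1CC[C@@H](OC(=O)Cc2cccnc2)CNC1=O)[C@H](O)[C@@H](O)[C@H](O)/C=C/C(C)(C)C`, has not yet been measured. It differs from compound 1 in one place: pyridin-3-yl in place of cyclohexyl on a saturated chain carbon bound to a carbonyl carbon. Going by the values given here, no measured pair shows this particular change, so the expectation rests only on the three numbers above and the change itself. A modest step toward a higher number is expected for the change from compound 1 to compound 4, a 2.0-fold higher number from compound 1 to compound 4 (0.30 log units; within the scatter), with a range wide enough that no change beyond the scatter is also plausible. Compound 4 is thus estimated at 120 nM, between 40 nM and 400 nM.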

Compound 4, half-maximal inhibitory concentration: 5850 nM
Compound 4: the middle estimate sits 49-fold (1.69 log units) below what was measured, and the stated range ends below it.
By their numbers in this assay, from the lowest: compound 3; then compounds 2 and 1 (each within the scatter of the next); then compound 4.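

At this position, on a saturated chain carbon bound to a carbonyl carbon, the two rings are far from interchangeable: in this assay, pyridin-3-yl in place of cyclohexyl gives a 98-fold higher number from compound 1 to compound 4 (1.99 log units; beyond the scatter), even though both groups have the same number of heavy atoms. Going by these compounds alone, the swap makes the ring aromatic, puts a nitrogen into it and adds a hydrogen-bond acceptor, and this single change is the first that can be read on its own, since the earlier compounds differ from one another in more than one place. Nothing available here explains the size of this loss.

A phenyl group on the same chain carbon would help separate the contribution of aromaticity from that of the ring nitrogen. From the compounds shown here alone, whether pyridin-2-yl or pyridin-4-yl would behave like pyridin-3-yl also remains open.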